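The source may report more compounds than this note shows. Statements on the series, on what has been measured and on what is new or still open speak of the compounds shown alone.

Measured compounds and values:

Compound 1, `O=C(/C=C/CCc1ccccc1)c1ccccc1F`: 1760 nM
Compound 2, `O=C(/C=C/CCc1ccccc1)c1cccc(F)c1`: 2370 nM
Compound 3, `O=C(/C=C/CCc1ccccc1)c1ccccc1-c1ccccc1`: 1230 nM

These three compounds were tested in a functional assay on HEK293 cells for antagonist activity at G-protein coupled receptor 52 (Homo sapiens), read by cAMP accumulation, with stated times of 15 min and 30 min; a lower number here means a stronger inhibitor, a higher number a weaker inhibitor. Compound 1 and compound 2 are built from the same atoms joined differently; the difference between the two cores is not broken down here. In this assay compound 1 gives 1760 nM and compound 2 gives 2370 nM, two numbers that lie within the usual scatter of each other.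

Compound 3 is made from compound 1 by one change, (phenyl in place of fluoro on an aromatic carbon), which sits ortho to a large group. The step of a 1.4-fold lower number from compound 1 to compound 3 (0.16 log units; within the scatter) is small enough to fall within the scatter of repeated measurements, so the data do not show this change doing much either way.

Compound 4, `O=C(/C=C/CCc1ccccc1)c1cccc(-c2ccccc2)c1`, has not yet been measured in this assay. It is made from compound 2 by the same kind of change, (phenyl in place of fluoro on an aromatic carbon), but here the new group sits meta to a large group rather than ortho to it, so the surroundings of the change are not the same. Among the measured compounds shown here, since the only example of this kind of change, a 1.4-fold lower number from compound 1 to compound 3 (0.16 log units; within the scatter), stayed within the scatter, a step of about the same size is expected from compound 2 to compound 4, that is a 1.4-fold lower number from compound 2 to compound 4 (0.14 log units; within the scatter). On that basis compound 4 is estimated at 1700 nM, with a likely range from 700 nM to 4000 nM.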

Compound 4, half-maximal inhibitory concentration: 8130 nM
For compound 4 the middle estimate is 4.8-fold (0.68 log units) below the measured one; measured number outside the range, above it.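

In this assay, phenyl in place of fluoro does not carry over cleanly from one core to the other, as the new result is a 3.4-fold higher number from compound 2 to compound 4 (0.54 log units; beyond the scatter), and set beside the earlier step, the two results disagree: the same change on two cores in this assay, a 1.4-fold lower number (0.16 log units; within the scatter) from compound 1 to compound 3 and a 3.4-fold higher number (0.54 log units; beyond the scatter) from compound 2 to compound 4, 4.9-fold (0.69 log units) apart, beyond the scatter of two such steps The practical lesson is that a step seen on one core is a poor guide to the same swap on its close relative, so here the step from compound 1 to compound 3 could not be reused for the phenyl that sits meta to a large group. What the data do not show is why the two steps part ways, or whether a general rule lies behind them, since this comparison rests on just two pairs of compounds and gives no cause for the gap.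

From the compounds shown here alone, it remains open whether the higher number of compound 4 is specific to phenyl or would also appear with a methyl, a methoxy or a chlorine atom at that same place on the ring. Going by these compounds, it is also open whether an amine or a carboxylic acid there, or a shorter chain leading to the other phenyl ring, would change how this swap behaves across the two cores.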